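This account rests on a few compounds, and the source may have more. Where it says the series, first, only, none or still open, it means among the compounds named here.

So far only two compounds built on the same core have been measured in a functional assay on SW-620 cells (Homo sapiens) for inhibition, read by sulforhodamine B assay, with a stated time of 48 h; a lower number here means a stronger inhibitor of growth, a higher number a weaker inhibitor of growth. Compound 1 (`O=C(Cc1csc2nc(-c3ccc(Br)cc3)cn12)N/N=C/c1ccccc1O`) gives 3980 nM, and compound 2 (`COc1cccc(OC)c1/C=N/NC(=O)Cc1csc2nc(-c3ccc(Br)cc3)cn12`) gives 6460 nM. Among the compounds with values here, the only measured step between them is a 1.6-fold higher number from compound 1 to compound 2 (0.21 log units; within the scatter), so compound 2 cannot be told apart from compound 1 on these numbers.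

Compound 3 (`O=C(Cc1csc2nc(-c3ccc(Br)cc3)cn12)N/N=C/c1ccc(Cl)cc1Cl`) has not yet been measured. The change from compound 2 is 2,4-dichlorophenyl in place of 2,6-dimethoxyphenyl on a carbon with a double bond to nitrogen. Put simply, 2,4-dichlorophenyl stands in place of 2,6-dimethoxyphenyl on a carbon with a double bond to nitrogen.

Within the data shown here, the one measured change at this place, a 1.6-fold higher number from compound 1 to compound 2 (0.21 log units; within the scatter), stayed within the scatter, and it is the only evidence available. On these data alone, neither compound 1 nor compound 2 carries chlorine, so the new group itself is untested and the range must stay wide. No step beyond the scatter is therefore expected in this assay, in either direction. The expected step is a 1.6-fold lower number from compound 2 to compound 3 (0.21 log units; within the scatter). For compound 3 the estimated value is 4000 nM, with an expected range from 1600 nM to 10000 nM.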

Compound 3, concentration for 50% growth inhibition: 22900 nM
Compound 3: middle estimate off by 5.7-fold (0.76 log units), on the low side; measured number outside the range, above it.
By their numbers in this assay, from the lowest: compounds 1 and 2 (each within the scatter of the next); then compound 3.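

In this assay, the group on the carbon with a double bond to nitrogen turns out to matter: 2,4-dichlorophenyl in place of 2,6-dimethoxyphenyl gives a 3.5-fold higher number from compound 2 to compound 3 (0.55 log units; beyond the scatter) and in place of 2-hydroxyphenyl gives a 5.8-fold higher number from compound 1 to compound 3 (0.76 log units; beyond the scatter) as well. Both steps are modest but lie beyond the scatter, which makes compound 3 the weakest growth inhibitor of the three, whereas compound 1 and compound 2 alone gave no sign that a change here could move the number beyond the scatter. Compound 1 and compound 2 both carry oxygen on this ring and compound 3 carries chlorine instead, but no measurement at hand explains the higher number of compound 3.

On these data alone, it remains open whether a plain phenyl ring, a ring with a single chlorine, or a ring carrying an amine or a carboxylic acid would fall with compound 1 and compound 2 or with compound 3. As far as these compounds go, it is also open whether the same change at this place would give a similar step with a different group elsewhere on the shared core.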